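Cytotoxicity of a diaryl ether sulfonamide: methyl for nitrile

A few compounds are considered here, and "the series" means these few. Any claim that something is new, unique, unknown or untested is made for them only; others in the source may bear on it.

Measured so far:
compound 1, `Cc1cc(S(N)(=O)=O)ccc1NC(=O)COc1ccc(Cl)cc1Oc1ccc2ccccc2c1Br`, gives 48100 nM
compound 2, `Cc1cc(S(N)(=O)=O)ccc1NC(=O)COc1ccc(Cl)cc1Oc1ccc2cc(C#N)ccc2c1`, gives > 383000 nM

Of the compounds shown here, two have been measured in an ADME assay on C8166 cells (Homo sapiens) for cytotoxicity, read by MTT assay; on this read-out lower numbers stand for higher toxicity in this test and higher numbers for lower toxicity in this test. Compound 1, `Cc1cc(S(N)(=O)=O)ccc1NC(=O)COc1ccc(Cl)cc1Oc1ccc2ccccc2c1Br`, gives 48100 nM in this assay. For compound 2, `Cc1cc(S(N)(=O)=O)ccc1NC(=O)COc1ccc(Cl)cc1Oc1ccc2cc(C#N)ccc2c1`, only a limit of the assay is known, > 383000 nM. Among the measured compounds shown here, the one measured step, an at least 7.9-fold higher number from compound 1 to compound 2 (0.90 log units; beyond the scatter), is therefore open-ended, as the limit of > 383000 nM in this assay, at which 1 of the 2 values shown sits, shows.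

Compound 3, `Cc1cc(S(N)(=O)=O)ccc1NC(=O)COc1ccc(Cl)cc1Oc1cc2ccccc2cc1C`, has not yet been measured. It differs from compound 2 in one place: 3-methylnaphthalen-2-yl in place of 6-cyanonaphthalen-2-yl on an oxygen on an aromatic ring. For the measured compounds named here, no measured step pairs a methyl against a nitrile on this naphthalene, so the expectation can rest only on the step from compound 1 to compound 2, which moved the number up out of the measurable range when a bromine was exchanged for a nitrile. Compound 3 carries neither, and its number is estimated to fall between the two measured points, with an at least 2.5-fold lower number from compound 2 to compound 3 (0.40 log units; beyond the scatter) as the expected step down from the limit of compound 2. Compound 3 is thus expected to give 150000 nM, within 40000 nM to 400000 nM, with a fair chance that only a limit is reported again.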

Compound 3, half-maximal cytotoxic concentration: 76700 nM
For compound 3 the middle estimate is 2.0-fold (0.29 log units) above the measured one; low and high end bracket the measured number.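

In this assay, the change to 3-methylnaphthalen-2-yl on this oxygen gives an at least 4.9-fold lower number from compound 2 to compound 3 (0.69 log units; beyond the scatter), so the number comes back into the measurable range once the 6-cyanonaphthalen-2-yl group is gone. Against the 1-bromonaphthalen-2-yl group, the same 3-methylnaphthalen-2-yl group gives a 1.6-fold higher number from compound 1 to compound 3 (0.20 log units; within the scatter), so the methyl and bromine compounds cannot be told apart here, and among these three compounds only the one carrying the nitrile stands out. The size of that separation remains open-ended, since compound 2 is known only through a limit of the assay: the limit of > 383000 nM in this assay, at which 1 of the 3 values shown sits.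

The compounds shown leave open whether the separation belongs to the nitrile itself or to where it sits on the naphthalene, since the nitrile, the methyl and the bromine each occupy a different place in their group names, so the group and its location change together. They also do not tell whether an amine or a carboxylic acid in the place the nitrile holds in compound 2 would again reach a limit of the assay.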